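A few compounds are considered here, and "the series" means these few. Any claim that something is new, unique, unknown or untested is made for them only; others in the source may bear on it.

Measured so far:
- compound 1 `CCC(CC)(c1ccc(OCC(=O)C(C)(C)C)c(C)c1)c1ccc(C(=O)NCCC(=O)OC)n1C`: 790 nM
- compound 2 `CCn1c(C(=O)N[C@@H](C)CO)ccc1C(CC)(CC)c1ccc(OCC(O)C(C)(C)C)c(C)c1`: 1.06 nM

Among the compounds with values here, in an assay on HL-60 cells for agonist activity at vitamin D3 receptor (Homo sapiens), with a stated time of 96 h (a higher number here means that more compound is needed for the effect, a lower number that less compound is needed), compound 1 gives 790 nM, the highest of the two numbers; compound 2 gives 1.06 nM, far lower and beyond the scatter, but the two differ in several places and no single step connects them. Compound 3 `CCC(CC)(c1ccc(OCC(=O)C(C)(C)C)c(C)c1)c1ccc(C(=O)N[C@@H](CC(=O)O)C(=O)O)n1C` differs from compound 1 in one place: 1,2-dicarboxyethyl in place of 2-(methoxycarbonyl)ethyl on an amide-type nitrogen. Within the data shown here, no measured pair shows this change, so its size and direction are unknown. Compound 3 is expected to give 1500 nM (range 300 nM to 8000 nM) in this assay, a step of a 1.9-fold higher number from compound 1 to compound 3 (0.28 log units; within the scatter) that is an estimate only, with no direction clearly favoured.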

Compound 3, half-maximal effective concentration: 410 nM
Compound 3: middle estimate off by 3.7-fold (0.56 log units), on the high side; low and high end bracket the measured number.
By their numbers in this assay, from the lowest: compound 2; then compounds 3 and 1 (each within the scatter of the next).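

On the amide-type nitrogen of the shared core, 1,2-dicarboxyethyl in place of 2-(methoxycarbonyl)ethyl brings a 1.9-fold lower number from compound 1 to compound 3 (0.28 log units; within the scatter) in this assay. This position therefore accepts two carboxylic acids and a defined stereocentre in place of the methyl ester, with no step beyond the scatter. No measurement available here accounts for this result.

Still open, on these data alone, is whether a single carboxylic acid, as in 2-carboxyethyl, or an aminoethyl chain on this nitrogen would stay within the scatter of compound 1. As far as these compounds go, the opposite stereoisomer of 1,2-dicarboxyethyl also remains open.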